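Swapping methoxy for hydroxy in compound 3

The compounds below may be only part of what the source reports. "The series", "measured", "known", "first", "only" and "open" are said of these compounds alone.

In a functional assay on MKN-45 cells (Homo sapiens) for inhibition, with a stated time of 72 h (on this read-out lower numbers stand for stronger inhibition and higher numbers for weaker inhibition), compound 1 `COc1ccc(S(=O)(=O)N2CCc3cccc(-c4ccc([N+](=O)[O-])cc4)c32)cc1` gives 34 nM, compound 2 `COc1ccc(S(=O)(=O)N2CCc3cccc(-c4ccc(F)cc4)c32)cc1` gives 79 nM and compound 3 `COc1ccc(-c2cccc3c2N(S(=O)(=O)c2ccc(OC)cc2)CC3)cc1` gives 211 nM, the highest of these numbers and so the weakest inhibition. Compound 4 `COc1ccc(S(=O)(=O)N2CCc3cccc(-c4ccc(O)cc4)c32)cc1` keeps the shared core, with hydrogen in place of methyl on an oxygen on an aromatic ring, turning methoxy to hydroxy: hydrogen in place of methyl on an oxygen on an aromatic ring. The closest evidence comes from swapping that methoxy group for others: a 2.7-fold higher number from compound 2 to compound 3 (0.43 log units; beyond the scatter) and a 6.2-fold higher number from compound 1 to compound 3 (0.79 log units; beyond the scatter), both modest. Neither step involves hydroxy, so the direction is uncertain, but a modest shift towards a lower number seems likeliest. The expected change is a 1.4-fold lower number from compound 3 to compound 4 (0.15 log units; within the scatter). Compound 4 is estimated at 150 nM, with an expected range of 50 nM to 450 nM.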

Compound 4, half-maximal inhibitory concentration: 82.6 nM
Beside the measured number, compound 4's estimate is 1.8-fold (0.26 log units) above it; the range from low to high includes it.
By their numbers in this assay, from the lowest: compound 1; then compounds 2 and 4 (each within the scatter of the next); then compound 3.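

Removing the methyl from the oxygen on the aromatic ring, methoxy to hydroxy, lowers the number (a 2.6-fold lower number from compound 3 to compound 4 (0.41 log units; beyond the scatter)). Hydroxy cannot be told apart from fluoro (a 1.0-fold higher number from compound 2 to compound 4 (0.02 log units; within the scatter)), while nitro still gives the lowest number of the set (a 2.4-fold higher number from compound 1 to compound 4 (0.39 log units; beyond the scatter)). No measurement here explains these differences. On these data alone, whether an amine or a carboxylic acid in this place would match hydroxy or nitro stays open. So does the effect of a longer chain on the oxygen, such as ethoxy.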